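The source may hold more compounds than are shown below. What is called first, only, known or untested is meant among the compounds shown, and "the series" means these compounds.

Measured so far in an ADME assay on MDBK cells (Bos taurus) for cytotoxicity, read by MTT assay, with a stated time of 96 h; a higher number here means that more compound is tolerated, a lower number that less compound is tolerated:
Compound 1 `COc1cccc(NC(=S)Nc2cccc(C(F)(F)F)c2)c1`: 52000 nM
Compound 2 `Fc1ccc(NC(=S)Nc2cccc(C(F)(F)F)c2)cc1`: 41000 nM
Compound 3 `Fc1ccccc1NC(=S)Nc1cccc(C(F)(F)F)c1`: > 100000 nM, a limit and not a number

Compound 3 sits at the limit of > 100000 nM in this assay, at which 1 of the 3 values shown sits. Compound 4 `Fc1cccc(NC(=S)Nc2cccc(C(F)(F)F)c2)c1` has not yet been measured. It differs from compound 3 as follows: 3-fluorophenyl in place of 2-fluorophenyl on an amide-type nitrogen. In short, 3-fluorophenyl stands in place of 2-fluorophenyl on an amide-type nitrogen.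

Within the data shown here, one measured step bears directly on this change. Exchanging 4-fluorophenyl for 2-fluorophenyl gave an at least 2.4-fold higher number from compound 2 to compound 3 (0.38 log units; beyond the scatter). The values of compound 1, 52000 nM, and compound 2, 41000 nM, lie within the scatter of each other. Only compound 3 reaches the limit, so compound 4 is expected to lose that standing and to fall near these two values. A drop of about the size of the measured step, in the opposite direction, is therefore expected. The expected change is an at least 2.0-fold lower number from compound 3 to compound 4 (0.30 log units; that floor lies within the scatter) in this assay. For compound 4 the estimated value is 50000 nM, with an expected range of 22000 nM to 100000 nM.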

Compound 4, half-maximal cytotoxic concentration: 10000 nM
The estimate for compound 4 lay 5.0-fold (0.70 log units) above the measured number; the whole stated range lies above it.
By their numbers in this assay, from the lowest: compound 4; then compounds 2 and 1 (each within the scatter of the next). At a limit, above all of these: compound 3.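

In this assay, the 3-fluorophenyl group proves the least tolerated of the three fluorophenyl groups, with an at least 10-fold lower number from compound 3 to compound 4 (1.00 log units; beyond the scatter) and a 4.1-fold lower number from compound 2 to compound 4 (0.61 log units; beyond the scatter). Compound 3 alone stands at a limit and not at a number: the limit of > 100000 nM in this assay, at which 1 of the 4 values shown sits. Fluoro in place of methoxy on an aromatic carbon also gives a 5.2-fold lower number from compound 1 to compound 4 (0.72 log units; beyond the scatter), whereas compound 1 and compound 2 had lain within the scatter of each other, so this pair alone gave no sign that this place could produce so clear a gap.

On these data alone, it remains open whether 3-chlorophenyl or 3-methylphenyl would track 3-fluorophenyl, and whether 2-chlorophenyl or 2-methoxyphenyl would share the standing of 2-fluorophenyl. The compounds shown also offer no measured property that would account for the order among the three fluorophenyl groups.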